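A few compounds are considered here, and "the series" means these few. Any claim that something is new, unique, unknown or untested is made for them only; others in the source may bear on it.

Compound 1 `Cc1ccc(S(=O)(=O)Oc2ccc3c(c2C)[C@H](Cn2cc(-c4ccccc4)nn2)[C@@]24CC(=O)[C@@](C)(CC[C@@H]32)C4)cc1`: > 20000 nM
Compound 2 `Cc1c(O)ccc2c1[C@H](Cn1cc(-c3ccc(Cl)cc3)nn1)[C@@]13CC(=O)[C@@](C)(CC[C@@H]21)C3`: > 20000 nM

Of the compounds shown here, two built on the same core have been tested in a functional assay on SMMC-7721 cells (Homo sapiens) for cytotoxicity, read by MTT assay, with a stated time of 4 days; a lower number here means a stronger inhibitor, a higher number a weaker inhibitor. For compound 1 the read-out is a limit, > 20000 nM. For compound 2 the read-out is likewise a limit, > 20000 nM. Among the compounds with values here, compound 2 therefore stands at the edge of what this assay can report, and the only other value shown sits there as well, as the limit of > 20000 nM in this assay, at which 2 of the 2 values shown sit, records. Compound 3 `Cc1ccc(S(=O)(=O)Oc2ccc3c(c2C)[C@H](Cn2cc(-c4ccc(Cl)cc4)nn2)[C@@]24CC(=O)[C@@](C)(CC[C@@H]32)C4)cc1` differs from compound 2 in one place: (4-methylphenyl)sulfonyl in place of hydrogen on an oxygen on an aromatic ring. Compound 1 already carries the same sulfonate ester on the same oxygen and still shows only a limit, so no step beyond the usual scatter is expected on going from compound 2 to compound 3, and most likely this assay again reports only a limit. The expected step reads a step that the limit leaves unreadable from compound 2 to compound 3. Compound 3 is accordingly estimated at 35000 nM, within a range from 8000 nM to 150000 nM.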

Compound 3, half-maximal inhibitory concentration: > 20000 nM
Compound 3 gave a limit, no number; the forecaster's own chance of this, stated with the estimate: 85%; the middle value does not contradict the limit.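

Within the data shown here, compound 1, compound 2 and compound 3 each give only a limit, so no step between them can be read: the limit of > 20000 nM in this assay, at which 3 of the 3 values shown sit.

The compounds shown leave open whether the chloro or the (4-methylphenyl)sulfonyl group changes the cytotoxicity at all, and how strong any of the three actually is.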